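Methylamide in place of acid across two cores

This account rests on a few compounds, and the source may have more. Where it says the series, first, only, none or still open, it means among the compounds named here.

Compound 1 `CNC(=O)CCc1ccncc1-c1ccc2ccccc2c1` gives in a functional assay on KB cells (Homo sapiens) for inhibition, read by sulforhodamine B assay, with a stated time of 72 h (a lower number here means a stronger inhibitor of growth, a higher number a weaker inhibitor of growth), only a limit, > 10000 nM.
Compound 2 `Cn1ccc2cc(-c3cnccc3/C=C/C(=O)O)ccc21` gives in this assay only a limit, > 10000 nM.
Compound 3 `O=C(O)CCc1ccncc1-c1ccc2ccccc2c1` gives in this assay only a limit, > 10000 nM.

The change methylamino in place of hydroxy on a carbonyl carbon gives a step that the two limits leave unreadable from compound 3 to compound 1; it is unreadable because of the limit of > 10000 nM in this assay, at which 3 of the 3 values shown sit. The difference between the core of compound 2 and the core of compound 3 is not broken down here. Compound 4 `CNC(=O)/C=C/c1ccncc1-c1ccc2c(ccn2C)c1` is not yet measured; it carries methylamino in place of hydroxy on a carbonyl carbon, the same kind of change as from compound 3 to compound 1, though the carbonyl carbon there neighbours a saturated chain carbon and here a double-bonded chain carbon. Since compound 2 stands at a limit > 10000 nM, the expected step of a number no higher from compound 2 to compound 4 (the limit leaves the size open) rests on nothing more than that limit. Compound 4 is estimated at 10000 nM, between 3000 nM and 30000 nM, most likely again a limit.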

Compound 4, concentration for 50% growth inhibition: 7080 nM
The estimate for compound 4 lay 1.4-fold (0.15 log units) above the measured number, within the range that was stated.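

In this assay, methylamino in place of hydroxy on a carbonyl carbon gives an at least 1.4-fold lower number from compound 2 to compound 4 (0.14 log units; that floor lies within the scatter). The step from compound 3 to compound 1 cannot be read, so the change has no readable size on either core and the two cores cannot be compared for it: the limit of > 10000 nM in this assay, at which 3 of the 4 values shown sit. Nothing here shows that the change carries from one core to the other, or that it does not.

Open, as far as these compounds go, is whether ethylamino or dimethylamino on the same carbonyl carbon would give a readable number in this assay. Also open, from the compounds shown here alone, is how a saturated chain and a double-bonded chain compare when both stand on one core.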